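A few compounds are considered here, and "the series" means these few. Any claim that something is new, unique, unknown or untested is made for them only; others in the source may bear on it.

Compound 2 `Cc1cncc(N2CC[C@@H]3CN[C@@H]3C2)c1` gives 1400 nM in a functional assay on HEK293 cells for agonist activity at Neuronal acetylcholine receptor; alpha3/beta4 (Homo sapiens), read by FLIPR (a higher number here means that more compound is needed for the effect, a lower number that less compound is needed), the highest of the two numbers seen so far. Compound 1 `Brc1cncc(N2CC[C@@H]3CN[C@@H]3C2)c1` gives 950 nM in this assay. For the measured compounds named here, the only measured step, a 1.5-fold higher number from compound 1 to compound 2 (0.17 log units; within the scatter), lies within the scatter. Compound 3 `N/C(=N/O)c1cncc(N2CC[C@@H]3CN[C@@H]3C2)c1` differs from compound 2 by a group of 4 heavy atoms (1 carbon, 2 nitrogen, 1 oxygen; no ring) in place of one carbon atom, on an aromatic carbon, a group of 4 heavy atoms in place of one carbon atom on an aromatic carbon. That single small step offers little guidance for a change of this size, so no direction is firmly indicated. Compound 3 is therefore expected to give 2500 nM in this assay, with a range from 600 nM to 10000 nM. This estimate amounts to a step of a 1.8-fold higher number from compound 2 to compound 3 (0.25 log units; within the scatter).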

Compound 3, half-maximal effective concentration: 5700 nM
Compound 3: the middle estimate sits 2.3-fold (0.36 log units) below what was measured, within the range that was stated.
By their numbers in this assay, from the lowest: compounds 1 and 2 (each within the scatter of the next); then compound 3.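

At this position, two atoms from the ring nitrogen, the number in this assay does respond to the group present: the entering group brings a 4.1-fold higher number from compound 2 to compound 3 (0.61 log units; beyond the scatter) and a 6.0-fold higher number from compound 1 to compound 3 (0.78 log units; beyond the scatter), both beyond the scatter, which the exchange of bromo and methyl did not show. The site is therefore not indifferent to every substituent. Nothing at hand bears on the reason for this rise. Still open, from the compounds shown here alone, is whether the higher number follows the number of heavy atoms or these particular atoms; an amine, a nitrile or a carboxylic acid on this carbon could begin to separate the two.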